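This account rests on a few compounds, and the source may have more. Where it says the series, first, only, none or still open, it means among the compounds named here.

Three compounds share one core and differ only in small attachments. In a functional assay on HT-29 cells (Homo sapiens) for cytotoxicity, read by MTT assay, with a stated time of 24 h (a lower number here means a stronger inhibitor, a higher number a weaker inhibitor), compound 1 `Cc1ccc2oc(-c3ccc(NC(=O)CN4CCN(CCCN(C)C)CC4)c(C)c3)nc2c1` gives 12700 nM. Compound 3 `Cc1ccc2oc(-c3ccc(NC(=O)CN4CCN(CCN(C)C)CC4)c(C)c3)nc2c1` gives 7240 nM in this assay. Compound 2 `Cc1ccc2oc(-c3ccc(NC(=O)CN4CCN(CCN(C)C)CC4)cc3)nc2c1` gives 1790 nM in this assay, the lowest of the three numbers, with both other compounds beyond the scatter above it. Two single-point steps link these compounds: a 1.8-fold lower number from compound 1 to compound 3 (0.24 log units; within the scatter) and a 4.0-fold higher number from compound 2 to compound 3 (0.61 log units; beyond the scatter).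

Compound 4 `CN(C)CCN1CCN(CC(=O)Nc2ccc(-c3nc4ccccc4o3)cc2)CC1` has not yet been measured. Compared with compound 2, the change is hydrogen in place of methyl on an aromatic carbon. For the measured compounds named here, no measured step touches this part of the core. Going by the values given here, the only methyl step, a 4.0-fold higher number from compound 2 to compound 3 (0.61 log units; beyond the scatter), concerns a methyl at another place in the molecule, so it gives only a loose guide: a methyl there shifted the number modestly, but a methyl elsewhere need not. With no closer evidence, the expected step in this assay is small, in either direction, and probably within the scatter.

Compound 4 is therefore expected to give about 2500 nM in this assay, most likely between 700 nM and 9000 nM. The estimated step is a 1.4-fold higher number from compound 2 to compound 4 (0.15 log units; within the scatter).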

Compound 4, half-maximal inhibitory concentration: 5310 nM
Beside the measured number, compound 4's estimate is 2.1-fold (0.33 log units) below it; the range from low to high includes it.
By their numbers in this assay, from the lowest: compound 2; then compounds 4, 3 and 1 (each within the scatter of the next, the first and the last beyond it).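

In this assay, taking the methyl away so that 5-methyl-1,3-benzoxazol-2-yl becomes 1,3-benzoxazol-2-yl gives a 3.0-fold higher number from compound 2 to compound 4 (0.47 log units; beyond the scatter), so a single methyl at this place shifts the number by more than the scatter. The two methyl steps also point in opposite directions: here the compound with the methyl has the lower number, whereas the methyl added on the other aromatic carbon goes with a 4.0-fold higher number from compound 2 to compound 3 (0.61 log units; beyond the scatter), so the effect of a methyl depends on where it sits in these compounds. No measurement here explains why this methyl changes the number.

The compounds shown leave open whether ethyl, methoxy or chlorine at this place would give a lower number than methyl does. They also leave open whether the methyl has the same effect with the longer dimethylaminopropyl chain of compound 1.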